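A few compounds are considered here, and "the series" means these few. Any claim that something is new, unique, unknown or untested is made for them only; others in the source may bear on it.

Working notes on the series.

Compound 1 `c1ccc(C[C@H](CCn2cncn2)c2ccccc2)cc1` gives 60.9 ug/mL in an ADME assay on HEp-2 cells (Homo sapiens) for cytotoxicity, read by MTT assay, with a stated time of 3 days (a higher number here means that more compound is tolerated, a lower number that less compound is tolerated), and compound 2 `c1ccc(C[C@@H](CCn2cncn2)c2ccccc2)cc1` gives 55.9 ug/mL. The pair differs only by the two compounds have the same atoms and bonds and differ only in configuration as drawn: 1 of 1 stereo elements differ; a stereocentre at a saturated chain carbon is drawn S in compound 2 and R in compound 1, and the step of a 1.1-fold lower number from compound 1 to compound 2 (0.04 log units; within the scatter) sits with the fact that compounds 1 and 2 differ only in the configuration as drawn. Compound 3 `Cc1ccc([C@H](CCn2cncn2)Cc2ccccc2)cc1` gives 152 ug/mL; against compound 2 the change is methyl in place of hydrogen on an aromatic carbon, and the step is a 2.7-fold higher number from compound 2 to compound 3 (0.43 log units; beyond the scatter).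

Compound 4 `Cc1ccc(C[C@H](CCn2cncn2)c2ccccc2)cc1` is not yet measured in this assay. From compound 1 it differs by methyl in place of hydrogen on an aromatic carbon, the same change as from compound 2 to compound 3, with the same place on the ring; the two cores differ by the two compounds have the same atoms and bonds and differ only in configuration as drawn: 1 of 1 stereo elements differ; a stereocentre at a saturated chain carbon is drawn S in compound 2 and R in compound 1. The step of a 2.6-fold higher number from compound 1 to compound 4 (0.42 log units; beyond the scatter) is expected to be of about the size of a 2.7-fold higher number from compound 2 to compound 3 (0.43 log units; beyond the scatter), resting on that step and on compound 1 at 60.9 ug/mL. Compound 4 is therefore estimated at 160 ug/mL, expected within 95 ug/mL to 270 ug/mL.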

Compound 4, half-maximal cytotoxic concentration: 38.8 ug/mL
Compound 4: middle estimate off by 4.1-fold (0.62 log units), on the high side, outside the stated range (below it).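

In this assay, methyl in place of hydrogen does not repeat its effect from one core to the other, the new step being a 1.6-fold lower number from compound 1 to compound 4 (0.20 log units; within the scatter): the same change on two cores in this assay, a 2.7-fold higher number (0.43 log units; beyond the scatter) from compound 2 to compound 3 and a 1.6-fold lower number (0.20 log units; within the scatter) from compound 1 to compound 4, 4.3-fold (0.63 log units) apart, beyond the scatter of two such steps. The two starting compounds stand within the scatter of each other, with a 1.1-fold lower number from compound 1 to compound 2 (0.04 log units; within the scatter), and the difference between them is limited to: the fact that compounds 1 and 2 differ only in the configuration as drawn. This shows that, for this pair of cores, the step on one core does not predict the step on the other, but it does not show why the steps part or establish a rule for the wider series.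

On these data alone, it remains open whether a larger or different group at that place, such as methoxy, chloro or an amine, would also behave differently on the two cores.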